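Sulfonamide series: aryl change on the sulfonyl sulfur

The source may hold more compounds than are shown below. What is called first, only, known or untested is meant among the compounds shown, and "the series" means these compounds.

Measured compounds:
compound 1 `CC(C)(C)c1ccc(CNCCCNS(=O)(=O)c2cc(C(F)(F)F)cc(C(F)(F)F)c2)cc1` 2300 nM
compound 2 `COc1cccc(CNCCCNS(=O)(=O)c2cc(C(F)(F)F)cc(C(F)(F)F)c2)c1` 3400 nM
compound 3 `O=S(=O)(NCCCCCCNCc1ccc(Br)cc1)c1ccccc1F` 13300 nM

In a functional assay on MIA PaCa-2 cells (Homo sapiens) for inhibition, read by MTT assay, with a stated time of 72 h (a higher number here means a weaker inhibitor of growth, a lower number a stronger inhibitor of growth), compound 3 gives the highest of the three numbers; compound 2 and compound 1 sit lower, both beyond the scatter. Compound 4 `O=S(=O)(NCCCCCCNCc1ccc(Br)cc1)c1ccc2ccsc2c1` differs from compound 3 in one place: 1-benzothiophen-6-yl in place of 2-fluorophenyl on a sulfonyl sulfur. Going by the values given here, the only measured single step, a 1.5-fold higher number from compound 1 to compound 2 (0.17 log units; within the scatter), concerns the aryl on the amine side and lies within the scatter, so it says nothing about the sulfonyl aryl. No measured pair varies that position; compound 1 and compound 2 carry a different sulfonyl aryl but also a different chain, so only their values are shown. Compound 4 is therefore expected near compound 3, with a modest move toward a lower number possible, a 1.5-fold lower number from compound 3 to compound 4 (0.17 log units; within the scatter). The estimate for compound 4 is 9000 nM, range 3500 nM to 25000 nM.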

Compound 4, concentration for 50% growth inhibition: 6000 nM
Compound 4: the middle estimate sits 1.5-fold (0.18 log units) above what was measured, and the stated range covers the measured number.
By their numbers in this assay, from the lowest: compounds 1, 2 and 4 (each within the scatter of the next, the first and the last beyond it); then compound 3.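

At the sulfonyl sulfur, the aryl group can shift the number in this assay: the first step measured at this position, a 2.2-fold lower number from compound 3 to compound 4 (0.35 log units; beyond the scatter), is modest but lies beyond the scatter. The change from 2-fluorophenyl to 1-benzothiophen-6-yl therefore moves growth inhibition in the stronger direction with the rest of compound 3 held constant. Nothing measured here explains the step.

Going by these compounds, it remains open whether a plain phenyl or a naphthyl group at this position would give a similar number. On these data alone, it is also open whether the step would hold with a shorter chain.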